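The source may report more compounds than this note shows. Statements on the series, on what has been measured and on what is new or still open speak of the compounds shown alone.

In a toxicity assay on HeLa cells (Homo sapiens) for cytotoxicity, read by MTT assay, with a stated time of 48 h (on this read-out higher numbers stand for weaker inhibition of growth and lower numbers for stronger inhibition of growth), compound 2 `COc1ccc2nc(Cl)c(/C=C3\SC(=S)NC3=O)cc2c1` gives only a limit, > 100 ug/mL. Compound 1 `CCOc1ccc2nc(Cl)c(/C=C3\SC(=S)NC3=O)cc2c1` likewise gives only a limit in this assay, > 100 ug/mL. Among the measured compounds shown here, the one step that touches this series, a step that the two limits leave unreadable from compound 1 to compound 2, cannot be read, since both values sit at the limit of > 100 ug/mL in this assay, at which 2 of the 2 values shown sit. Compound 3 `O=C1NC(=S)S/C1=C\c1cc2cc(F)ccc2nc1Cl` differs from compound 2 by fluoro in place of methoxy on an aromatic carbon. With no readable step to rest on, no direction beyond the scatter can be set for compound 3, and it is expected to stay at the limit of this assay. Compound 3 is estimated at 150 ug/mL, within 50 ug/mL to 500 ug/mL. The step this estimate implies, a step that the limit leaves unreadable from compound 2 to compound 3, is expected to mean no change beyond the scatter.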

Compound 3, concentration for 50% growth inhibition: > 100 ug/mL
Compound 3 gave a limit, no number; the forecaster's own chance of this, stated with the estimate: 75%; the middle value is on the limit's open side.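

Compound 3, like compound 1 and compound 2, gives only a limit, so no step among these compounds can be read: the limit of > 100 ug/mL in this assay, at which 3 of the 3 values shown sit.

The compounds shown leave open whether any change at this place on the shared core can shift the result in this assay.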